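The compounds below may be only part of what the source reports. "The series", "measured", "known", "first", "only" and "open" are said of these compounds alone.

Values so far in a functional assay on K562 cells (Homo sapiens) for antiproliferative activity, read by MTT assay, with a stated time of 72 h (on this read-out lower numbers stand for stronger inhibition and higher numbers for weaker inhibition), are these:
- compound 1 `O=C(/C=C/c1ccc(/C=C/C(=O)c2ccccc2)cc1)NO` at 2280 nM
- compound 2 `O=C(/C=C/c1ccc(/C=C/C(=O)c2ccccc2)cn1)NO` at 690 nM
- compound 3 `CN1CCN(c2ccccc2C(=O)/C=C/c2ccc(/C=C/C(=O)NO)nc2)CC1` at 1220 nM

Compound 2 sits at the low end of these numbers, level within the scatter with compound 3, while compound 1 lies on the higher side, beyond the scatter.

Next in line is compound 4 `CN1CCN(c2cccc(C(=O)/C=C/c3ccc(/C=C/C(=O)NO)nc3)c2)CC1`, whose change from compound 2 is 4-methylpiperazin-1-yl in place of hydrogen on an aromatic carbon, with 4-methylpiperazin-1-yl in place of hydrogen on an aromatic carbon, meta to a large group.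

Going by the values given here, only one measured step bears on this change. It is a 1.8-fold higher number from compound 2 to compound 3 (0.25 log units; within the scatter), and it brings in the same group on an aromatic carbon at another place. A single step shows no pattern, and the data do not show what the place of the group does to the number.

The same direction is therefore expected, on a similar small scale, with no step beyond the scatter. The expected step is a 1.4-fold higher number from compound 2 to compound 4 (0.14 log units; within the scatter) on this estimate, read again in this assay once measured.

For compound 4 the estimate is 950 nM, with an expected range from 400 nM to 2200 nM in this read-out.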

Compound 4, half-maximal inhibitory concentration: 360 nM
Beside the measured number, compound 4's estimate is 2.6-fold (0.42 log units) above it; the whole stated range lies above it.
By their numbers in this assay, from the lowest: compounds 4, 2, 3 and 1 (each within the scatter of the next, the first and the last beyond it).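

In this assay, a 1.9-fold lower number from compound 2 to compound 4 (0.28 log units; within the scatter), so a 4-methylpiperazin-1-yl group on an aromatic carbon, meta to a large group, leaves the number level with that of the parent bearing hydrogen. Together with a 1.8-fold higher number from compound 2 to compound 3 (0.25 log units; within the scatter), this gives two placements of the same group on that ring, and neither step leaves the scatter, so across these three compounds the added ring of 7 heavy atoms is accommodated without a measurable loss. The placements do not read identically in the printed values, with compound 3 at 1220 nM and compound 4 at 360 nM, which gives the first sign that the place of the group may matter, although two compounds are a thin basis for any positional rule.

Still open, from the compounds shown here alone, is whether the result at this position belongs to the 4-methylpiperazin-1-yl group in particular or would extend to a morpholine, a piperazine without the methyl, a dimethylamino group or a carboxylic acid at the same carbon. Nothing available here bears on why the numbers fall as they do, whether at this position or at the other.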